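Vinylcarbonyl on the amino nitrogen: expectation for compound 4

The compounds below may be only part of what the source reports. "The series", "measured", "known", "first", "only" and "open" are said of these compounds alone.

Compound 2 `Cc1ccc(NC(=O)Nc2ccc(Oc3cc(N)ncn3)cc2)cc1C(F)(F)F` stands at a limit of the assay, > 10000 nM in a functional assay on BaF3 cells (Mus musculus) for inhibition, read by CCK-8 assay, with a stated time of 72 h; on this read-out lower numbers stand for stronger inhibition of growth and higher numbers for weaker inhibition of growth. Compound 1 `Cc1ccc(NC(=O)Nc2ccc(Oc3cc(NCc4ccccc4)ncn3)cc2)cc1C(F)(F)F` gives 3010 nM in this assay, and compound 3 `Cc1ccc(NC(=O)Nc2ccc(Oc3cc(N4CCNC[C@H]4C)ncn3)cc2)cc1C(F)(F)F` gives 9670 nM. The change to compound 4 `C=CC(=O)Nc1cc(Oc2ccc(NC(=O)Nc3ccc(C)c(C(F)(F)F)c3)cc2)ncn1` is vinylcarbonyl in place of hydrogen on a nitrogen on an aromatic ring, amino to (vinylcarbonyl)amino. The nearest measured step runs in the opposite direction: an at least 3.3-fold higher number from compound 1 to compound 2 (0.52 log units; beyond the scatter), so stripping a substituent from this nitrogen cost potency. By contrast an at least 1.0-fold lower number from compound 2 to compound 3 (0.01 log units; that floor lies within the scatter), with the limit (the limit of > 10000 nM in this assay, at which 1 of the 3 values shown sits) holding when 2-methylpiperazin-1-yl replaces amino. Re-substituting the nitrogen is therefore expected to lower the number, roughly as an at least 3.3-fold lower number from compound 2 to compound 4 (0.52 log units; beyond the scatter). Compound 4 is estimated near 3000 nM, within 800 nM to 12000 nM.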

Compound 4, concentration for 50% growth inhibition: 1940 nM
Beside the measured number, compound 4's estimate is 1.5-fold (0.19 log units) above it, within the range that was stated.
By their numbers in this assay, from the lowest: compounds 4 and 1 (each within the scatter of the next); then compound 3. At a limit, above all of these: compound 2.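

In this assay compound 2 stands at a limit, which is not a number: the limit of > 10000 nM in this assay, at which 1 of the 4 values shown sits. Vinylcarbonyl on this nitrogen gives an at least 5.1-fold lower number from compound 2 to compound 4 (0.71 log units; beyond the scatter), so a non-ring acyl group brings a measurable value here, and replacing 2-methylpiperazin-1-yl with (vinylcarbonyl)amino gives a 5.0-fold lower number from compound 3 to compound 4 (0.70 log units; beyond the scatter). Benzyl and vinylcarbonyl on this nitrogen cannot be told apart, with a 1.6-fold lower number from compound 1 to compound 4 (0.19 log units; within the scatter).

Whether the vinyl double bond matters remains open, since a saturated propanoyl or a smaller acetyl group on this nitrogen is not among the compounds shown.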